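The source may report more compounds than this note shows. Statements on the series, on what has been measured and on what is new or still open speak of the compounds shown alone.

Among the measured compounds shown here, compound 2 `CCc1cc2[nH]ncc2cc1-c1ccccc1C(F)(F)F` gives 50 nM in an assay on CHO-TREX cells for antagonist activity at transient receptor potential cation channel subfamily A member 1 (Homo sapiens), read by FLIPR and calcium flux, with a stated time of 10 min (a lower number here means a stronger inhibitor, a higher number a weaker inhibitor), the lower of the two numbers measured so far. Compound 1 `FC(F)(F)c1ccccc1-c1ccc2[nH]ncc2c1` carries hydrogen where compound 2 carries ethyl; in this assay compound 1 gives 164 nM, and the step of a 3.3-fold lower number from compound 1 to compound 2 (0.52 log units; beyond the scatter) lies beyond the scatter. Compound 3 `CC(C)c1cc2[nH]ncc2cc1-c1ccccc1C(F)(F)F` is compound 2 with methyl in place of hydrogen on a saturated chain carbon bound to an aromatic carbon and a saturated chain carbon. For the measured compounds named here, no measured step tests exactly this change; the only step known, a 3.3-fold lower number from compound 1 to compound 2 (0.52 log units; beyond the scatter), shows that replacing hydrogen by ethyl lowered the number, so a small further drop, or none beyond the scatter, is expected. Compound 3 is therefore expected to give 40 nM, between 15 nM and 120 nM. This corresponds to an expected step of a 1.3-fold lower number from compound 2 to compound 3 (0.10 log units; within the scatter).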

Compound 3, half-maximal inhibitory concentration: 25400 nM
Compound 3: middle estimate off by 640-fold (2.80 log units), on the low side; the whole stated range lies below it.
By their numbers in this assay, from the lowest: compound 2; then compound 1; then compound 3.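

At this aromatic carbon, a larger group does not keep lowering the number: ethyl gave a gain over hydrogen, yet turning ethyl into isopropyl gives a 510-fold higher number from compound 2 to compound 3 (2.71 log units; beyond the scatter) and erases it. With hydrogen as the reference, isopropyl gives a 150-fold higher number from compound 1 to compound 3 (2.19 log units; beyond the scatter), so this single added methyl goes far past cancelling the gain from ethyl. Nothing available here bears on why the number rises so sharply. The compounds shown leave open whether branching itself or overall size sets this limit. A straight propyl chain or a methoxy group at the same carbon would help separate the two.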